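Fluoro for Methyl on the Fused Ring of Compound 1

A few compounds are considered here, and "the series" means these few. Any claim that something is new, unique, unknown or untested is made for them only; others in the source may bear on it.

Measured compounds in an assay on isolated protein for displacement of a labelled ligand from metabotropic glutamate receptor 5 (Homo sapiens), with a stated time of 60 min, tested at 1 uM; a higher number here means more inhibition at the concentration tested (going by the name of the read-out), a lower number less inhibition:
Compound 1 `Cc1ccc2ncc(S(=O)(=O)c3ccc(F)cc3)c(N3CCC(C)CC3)c2c1` gives 90%.
Compound 2 `Cc1ccc(S(=O)(=O)c2cnc3ccc(Cl)cc3c2N2CCC(C)CC2)cc1C` gives 84%.
Compound 3 `Cc1ccc(S(=O)(=O)c2cnc3ccc(Cl)cc3c2N2CCC(C)CC2)cc1F` gives 68%.

Compound 1 stands highest of the three; the number for compound 2 lies within the scatter of it, while compound 3 lies beyond the scatter below it. The difference between the core of compound 1 and the core of compound 2 is not broken down here.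

Between compound 2 and compound 3 the change is fluoro in place of methyl on an aromatic carbon and it made the step of a number 16 percentage points lower from compound 2 to compound 3 (beyond the scatter).

Compound 4 `CC1CCN(c2c(S(=O)(=O)c3ccc(F)cc3)cnc3ccc(F)cc23)CC1` has not yet been measured in this assay. It differs from compound 1 by fluoro in place of methyl on an aromatic carbon. This is the same kind of change as that from compound 2 to compound 3, but not the same: there the fluoro sat ortho to a methyl group and meta to a large group, whereas here it sits on a ring that is part of a fused system, meta and para to a fused ring.

The step is estimated at a number 12 percentage points lower from compound 1 to compound 4 (beyond the scatter), a modest fall like the earlier one, resting on compound 1 at 90% and on the step of a number 16 percentage points lower from compound 2 to compound 3 (beyond the scatter). Compound 4 is therefore expected to give about 78%, with 60% to 92% as its likely range.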

Compound 4, a percentage reported as inhibition, at one concentration (the size of the read-out at that concentration, not a potency): 87%
Compound 4: middle estimate off by 9 percentage points, on the low side; the measured number falls inside the stated range.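

In this assay, the step on the core of compound 1 came out as a number 3 percentage points lower from compound 1 to compound 4 (within the scatter), so there fluoro in place of methyl on an aromatic carbon left no difference that can be told from the scatter. Set beside the earlier step, this one cannot be told apart from it, so the series gives no ground for saying that the change behaves differently on the two cores: the same change on two cores in this assay, a number 16 percentage points lower (beyond the scatter) from compound 2 to compound 3 and a number 3 percentage points lower (within the scatter) from compound 1 to compound 4, 13 percentage points apart, within the scatter of two such steps

Among the compounds shown here, this does not show that the change carries over reliably, since it rests on only two pairs, the change sits at a different place in each, and a percentage at one concentration is not a potency.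

The compounds shown leave open whether another group on the same aromatic carbon of the core of compound 1, such as a methoxy or a nitrile, would give a number like that of compound 4. They also leave open whether the same change would look alike on a core carrying an amine or a carboxylic acid.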